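The source may hold more compounds than are shown below. What is called first, only, known or untested is meant among the compounds shown, and "the series" means these compounds.

Values in a functional assay on CHO cells for positive allosteric modulation of metabotropic glutamate receptor 2 (Homo sapiens), with a stated time of 30 min; a lower number here means that less compound is needed, a higher number that more compound is needed for the effect:
compound 1, `N#Cc1c(N2CCC(c3ccccc3)CC2)ccn(CC2CC2)c1=O`: 151 nM
compound 2, `N#Cc1c(N2CCC(c3cccc(F)c3)CC2)ccn(CC2CC2)c1=O`: 141 nM

For the measured compounds named here, compound 2 holds the lowest of the two numbers, but the only neighbour is compound 1, and the step of a 1.1-fold lower number from compound 1 to compound 2 (0.03 log units; within the scatter) lies within the scatter, so the two compounds cannot be told apart on these data. The change on that step was a fluoro in place of hydrogen on an aromatic carbon of the phenyl ring.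

Compound 3, `N#Cc1c(N2CCC(c3cccc(C(F)(F)F)c3)CC2)ccn(CC2CC2)c1=O`, has not yet been measured. It differs from compound 2 by trifluoromethyl in place of fluoro on an aromatic carbon, a trifluoromethyl in place of fluoro on an aromatic carbon of a six-membered aromatic ring of carbon only, meta to a large group; one fluorine leaves and one carbon with three fluorines enters.

Going by the values given here, the single measured step that touches this position, a 1.1-fold lower number from compound 1 to compound 2 (0.03 log units; within the scatter), showed no effect beyond the scatter. Among the compounds with values here, no measured compound carries a trifluoromethyl or any group of similar size there, so the data give no direction for a larger substituent. The expected step is therefore small, a 1.1-fold higher number from compound 2 to compound 3 (0.03 log units; within the scatter), with a wide range to allow for the unknown. Compound 3 in this assay is estimated at 150 nM, between 50 nM and 450 nM.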

Compound 3, half-maximal effective concentration: 46 nM
The estimate for compound 3 lay 3.3-fold (0.51 log units) above the measured number; measured number outside the range, below it.
By their numbers in this assay, from the lowest: compound 3; then compounds 2 and 1 (each within the scatter of the next).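

Up to this point, the position on the six-membered aromatic ring of carbon only looked indifferent in this assay, since fluoro in place of hydrogen gave only a 1.1-fold lower number from compound 1 to compound 2 (0.03 log units; within the scatter) and left compound 1 and compound 2 within the scatter of each other. Trifluoromethyl shows that the position can respond to what is placed there, with a 3.1-fold lower number from compound 2 to compound 3 (0.49 log units; beyond the scatter) and, against the compound carrying hydrogen, a 3.3-fold lower number from compound 1 to compound 3 (0.52 log units; beyond the scatter) in the same direction. The change replaces a group of 1 heavy atom with one of 4 heavy atoms, neither with hydrogen-bond donors or acceptors, but nothing available here explains why the number falls with trifluoromethyl and not with fluoro.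

Going by these compounds, what remains open is whether this lower number is particular to trifluoromethyl, as a methyl, a chlorine, a methoxy group or an amine at the same place would help to show. On these data alone, all three compounds share one core and differ at this one position, so the effect of trifluoromethyl elsewhere on the ring, or on a different core, remains unknown.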